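The compounds below may be only part of what the source reports. "The series", "measured", "known", "first", "only" and "open" are said of these compounds alone.

Working notes on the series. All four compounds share the core of compound 1 `Cc1c(C2CC2)nc2ccc(-n3ccc(OCc4ccc(Br)cc4)cc3=O)cn12`, which in an assay on CHO cells for displacement of a labelled ligand from melanin-concentrating hormone receptor 1 (Rattus norvegicus), read by scintillation counting, with a stated time of 1 h (a higher number here means a weaker inhibitor, a lower number a stronger inhibitor), gives 9.3 nM. Compound 2 `Cc1c(C2CC2)nc2ccc(-n3ccc(OCc4ccc(C(C)C)cc4)cc3=O)cn12` gives 240 nM in this assay. Compound 3 `Cc1c(C2CC2)nc2ccc(-n3ccc(OCc4cncnc4)cc3=O)cn12` is known in this assay only as a limit, > 1000 nM, not as a number (the limit of > 1000 nM in this assay, at which 1 of the 3 values shown sits). The two steps that arrive at compound 3 are both beyond the scatter: an at least 100-fold higher number from compound 1 to compound 3 (2.03 log units; beyond the scatter) and an at least 4.1-fold higher number from compound 2 to compound 3 (0.61 log units; beyond the scatter). The two aryl variants themselves also lie apart, since a 26-fold higher number from compound 1 to compound 2 (1.41 log units; beyond the scatter).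

Compound 4 `Cc1c(C2CC2)nc2ccc(-n3ccc(OCc4csc(C(F)(F)F)c4)cc3=O)cn12` is not yet measured. The change is 5-(trifluoromethyl)thiophen-3-yl in place of pyrimidin-5-yl on a saturated chain carbon bound to an oxygen on an aromatic ring. It runs in the opposite direction to the two measured steps onto compound 3, each of which exchanged a substituted phenyl, 4-bromophenyl or 4-isopropylphenyl, for pyrimidin-5-yl and lost binding by a large amount whose full size is hidden behind the limit. A large move to a lower number is therefore expected, with its size uncertain between the outcomes seen for compound 1 and compound 2. Compound 4 is expected to give about 30 nM in this assay, estimated between 7 nM and 150 nM. The expected step is an at least 33-fold lower number from compound 3 to compound 4 (1.52 log units; beyond the scatter).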

Compound 4, half-maximal inhibitory concentration: 15 nM
The estimate for compound 4 lay 2.0-fold (0.30 log units) above the measured number, within the range that was stated.
By their numbers in this assay, from the lowest: compounds 1 and 4 (each within the scatter of the next); then compound 2. At a limit, above all of these: compound 3.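

The position on the saturated chain carbon bound to an oxygen on an aromatic ring is not confined to substituted phenyl groups: in this assay, 5-(trifluoromethyl)thiophen-3-yl, a five-membered aromatic ring, matches 4-bromophenyl within the scatter (a 1.6-fold higher number from compound 1 to compound 4 (0.21 log units; within the scatter)) and clearly improves on 4-isopropylphenyl (a 16-fold lower number from compound 2 to compound 4 (1.20 log units; beyond the scatter)). A heteroaromatic ring at this place can therefore retain binding, as the large step away from pyrimidin-5-yl also shows (an at least 66-fold lower number from compound 3 to compound 4 (1.82 log units; beyond the scatter)). Compound 3 stands only as a limit, so that step is a bound and its full size stays hidden: the limit of > 1000 nM in this assay, at which 1 of the 4 values shown sits.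

Compound 4 changes the ring and its substituent together, which leaves the contributions of the thiophene ring and the trifluoromethyl group unseparated. Also open, on these data alone, is how unsubstituted thiophen-3-yl or 4-(trifluoromethyl)phenyl would read in this assay.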